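A few compounds are considered here, and "the series" means these few. Any claim that something is new, unique, unknown or untested is made for them only; others in the source may bear on it.

Measured so far:
compound 1 `CC(C)n1ncc2c(C(=O)Nc3cccc(C(N)=O)c3)cc(-c3cccs3)nc21`: 25000 nM
compound 2 `CC(C)n1ncc2c(C(=O)Nc3ccc(F)cc3)cc(-c3ccco3)nc21`: > 200000 nM

Among the compounds with values here, in an ADME assay on LLC-MK2 cells (Macaca mulatta) for cytotoxicity, read by spectrophotometry and crystal violet staining, with a stated time of 4 days (on this read-out higher numbers stand for lower toxicity in this test and lower numbers for higher toxicity in this test), compound 1 gives 25000 nM, the only number in this set. Compound 2 returns > 200000 nM, which is a limit of the assay rather than a number. Compound 2 therefore sits at the limit of > 200000 nM in this assay, at which 1 of the 2 values shown sits. Within the data shown here, compound 1 stands as the sole measured point, and no step between measured compounds can be sized from the two entries.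

Compound 3 `CC(C)n1ncc2c(C(=O)Nc3cc(F)ccc3F)cc(-c3cccs3)nc21` is not yet measured. It differs from compound 1 in one place: 2,5-difluorophenyl in place of 3-carbamoylphenyl on an amide-type nitrogen. Among the measured compounds shown here, with no measured step to lean on, the step from compound 1 to compound 3 is expected to be modest and toward lower toxicity, a 2.4-fold higher number from compound 1 to compound 3 (0.38 log units; beyond the scatter), with a real chance that compound 3 also returns only a limit. Compound 3 is estimated at 60000 nM in this assay, with a range from 15000 nM to 200000 nM.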

Compound 3, half-maximal cytotoxic concentration: 100000 nM
The estimate for compound 3 lay 1.7-fold (0.22 log units) below the measured number, and the stated range covers the measured number.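

In this assay, within the data shown here, the one change on the amide-type nitrogen gives a 4.0-fold higher number from compound 1 to compound 3 (0.60 log units; beyond the scatter), so this place on the shared core moves the read-out toward lower toxicity in this test, while compound 3 still returns a number and not a limit. The change takes away a group with a hydrogen-bond donor and acceptor and brings in one with neither, along with two fluorines, so the contribution of each part cannot be separated. Nothing measured for these compounds gives a cause for the step.

As far as these compounds go, it remains open how far an unsubstituted phenyl on the same nitrogen would account for the step. Also open, from the compounds shown here alone, is how an amine or a carboxylic acid in place of the carbamoyl group would read in this assay.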